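Branched Alkyl for Methoxymethyl at the Chain Carbon

The source may report more compounds than this note shows. Statements on the series, on what has been measured and on what is new or still open speak of the compounds shown alone.

Measured compounds:
compound 1, `COc1cc(Cc2nc3c(N)ncnc3n2CC2CCCCC2)cc(OC)c1OC`, 39800 nM
compound 2, `COc1cc(Cc2nc3c(N)ncnc3n2CC(C)C)cc(OC)c1OC`, 97700 nM
compound 3, `COCCn1c(Cc2cc(OC)c(OC)c(OC)c2)nc2c(N)ncnc21`, 64600 nM

In a functional assay on MCF7 cells (Homo sapiens) for antiproliferative activity (on this read-out higher numbers stand for weaker inhibition and lower numbers for stronger inhibition), compound 3 stands second highest of the three numbers; its nearest neighbour is compound 2, and the two values lie within the scatter of each other, as do those of compound 3 and compound 1. For the measured compounds named here, the only step beyond the scatter is a 2.5-fold higher number from compound 1 to compound 2 (0.39 log units; beyond the scatter).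

Compound 4, `CCC(C)Cn1c(Cc2cc(OC)c(OC)c(OC)c2)nc2c(N)ncnc21`, has not yet been measured. It differs from compound 3 by sec-butyl in place of methoxymethyl on a saturated chain carbon bound to an aromatic nitrogen. Going by the values given here, the steps that bear on this exchange all concern the same saturated chain carbon bound to an aromatic nitrogen: a 1.5-fold lower number from compound 2 to compound 3 (0.18 log units; within the scatter), a 1.6-fold higher number from compound 1 to compound 3 (0.21 log units; within the scatter) and a 2.5-fold higher number from compound 1 to compound 2 (0.39 log units; beyond the scatter). Exchanging a methoxymethyl for an isopropyl, a branched chain of the same kind as sec-butyl, stayed within the scatter, so no step beyond the scatter is expected in this assay from compound 3 to compound 4, with a lean towards a slightly higher number because of a 1.5-fold lower number from compound 2 to compound 3 (0.18 log units; within the scatter) read backwards. The expected step is a 1.2-fold higher number from compound 3 to compound 4 (0.06 log units; within the scatter). Compound 4 is therefore estimated at 75000 nM, within a range from 30000 nM to 190000 nM.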

Compound 4, half-maximal inhibitory concentration: 61700 nM
For compound 4 the middle estimate is 1.2-fold (0.08 log units) above the measured one, within the range that was stated.
By their numbers in this assay, from the lowest: compounds 1, 4, 3 and 2 (each within the scatter of the next, the first and the last beyond it).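

In this assay, replacing methoxymethyl, which carries a hydrogen-bond acceptor, with sec-butyl, which carries none, gives a 1.0-fold lower number from compound 3 to compound 4 (0.02 log units; within the scatter), so this position tolerated the exchange of an oxygen-bearing chain for an all-carbon one without a step beyond the scatter. Methyl in place of hydrogen on a saturated chain carbon, three bonds along the chain from an aromatic nitrogen, gives a 1.6-fold lower number from compound 2 to compound 4 (0.20 log units; within the scatter), and sec-butyl in place of cyclohexyl gives a 1.6-fold higher number from compound 1 to compound 4 (0.19 log units; within the scatter); compound 4 thus lies within the scatter of each of the other three compounds, and the only step beyond it remains the one separating the cyclohexyl and isopropyl compounds. No available evidence explains why these different chains give such closely spaced numbers.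

From the compounds shown here alone, it remains open whether an amine, a carboxylic acid or a longer chain at this position would produce a step beyond the scatter. Going by these compounds, because all four compounds share the rest of the structure, it is also open whether these chains would compare in the same way on a different core.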